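Chloro placement on the chalcone aryl of a thiazole series

This account rests on a few compounds, and the source may have more. Where it says the series, first, only, none or still open, it means among the compounds named here.

Measured compounds and values in a functional assay on Bel-7402 cells (Homo sapiens) for cytotoxicity, read by MTT assay; on this read-out lower numbers stand for stronger inhibition and higher numbers for weaker inhibition:
compound 1, `Cc1cccc(Nc2nc(C)c(C(=O)/C=C/c3ccccc3Cl)s2)c1`, gives > 25000 nM, a limit.
compound 2, `Cc1nc(Nc2cccc(Cl)c2)sc1C(=O)/C=C/c1ccc(Cl)cc1`, gives > 25000 nM, a limit.
compound 3, `Cc1cccc(Nc2nc(C)c(C(=O)/C=C/c3ccccc3)s2)c1`, gives > 25000 nM, a limit.

Among the measured compounds shown here, compound 3 stands where the other two stand: all three values shown sit at the same limit of this assay, so no member of the set is separated from another. For the measured compounds named here, the only single-point step between measured compounds, a step that the two limits leave unreadable from compound 1 to compound 3, cannot be read in size, because the limit of > 25000 nM in this assay, at which 3 of the 3 values shown sit, applies to both ends of it.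

Compound 4, `Cc1cccc(Nc2nc(C)c(C(=O)/C=C/c3ccc(Cl)cc3)s2)c1`, differs from compound 3 by chloro in place of hydrogen on an aromatic carbon. Compound 2 already carries the same 4-chlorophenyl on the enone, and compound 2 sits at the limit, as do compound 1 and compound 3; the two values are within the scatter of each other and show no movement.

Going by the values given here, no step of readable size bears on the change. The expectation is therefore that compound 4 also returns a limit, with a step that the limit leaves unreadable from compound 3 to compound 4 expected to be no step beyond the scatter. Compound 4 is expected at 40000 nM, within 12000 nM to 150000 nM, and most likely reported only as a limit in this assay.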

Compound 4, half-maximal inhibitory concentration: > 25000 nM
Compound 4 gave a limit, no number; the forecaster's own chance of this, stated with the estimate: 85%; the middle value lies beyond the limit too.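

No new step can be read: the steps from compound 1, compound 2 and compound 3 to compound 4 are all unreadable in size, because each end of them lies at one limit: the limit of > 25000 nM in this assay, at which 4 of the 4 values shown sit.

The compounds shown leave open whether phenyl, 2-chlorophenyl or 4-chlorophenyl on the enone makes any difference in this assay, and what potency any of the four actually has.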